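Pyridin-4-yl aryl swap on the hydrazone of compound 3

The compounds below may be only part of what the source reports. "The series", "measured", "known", "first", "only" and "open" are said of these compounds alone.

Three hydrazone-urea analogues sharing one core have been measured in a functional assay on MKN-45 cells (Homo sapiens) for cytotoxicity, read by MTT assay, with a stated time of 72 h; on this read-out higher numbers stand for weaker inhibition and lower numbers for stronger inhibition. Compound 1 `COc1ccc(/C=N/NC(=O)Nc2ccc(Oc3ccnc4cc(OCCCN5CCCCC5)c(OC)cc34)c(F)c2)cc1` gives 660 nM. Compound 2 `COc1cc2c(Oc3ccc(NC(=O)N/N=C/c4ccc(C(F)(F)F)cc4)cc3F)ccnc2cc1OCCCN1CCCCC1` gives 630 nM. Compound 3 `COc1cc2c(Oc3ccc(NC(=O)N/N=C/c4ccc(N(C)C)cc4)cc3F)ccnc2cc1OCCCN1CCCCC1` gives 870 nM, the highest number of the three, though each of its steps to the other two lies within the scatter: a 1.3-fold higher number from compound 1 to compound 3 (0.12 log units; within the scatter) and a 1.4-fold higher number from compound 2 to compound 3 (0.14 log units; within the scatter). The remaining step, a 1.0-fold lower number from compound 1 to compound 2 (0.02 log units; within the scatter), is likewise within the scatter, so the three substituents on the aryl ring of the hydrazone leave this assay unchanged.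

Compound 4 `COc1cc2c(Oc3ccc(NC(=O)N/N=C/c4ccncc4)cc3F)ccnc2cc1OCCCN1CCCCC1` differs from compound 3 by pyridin-4-yl in place of 4-(dimethylamino)phenyl on a carbon with a double bond to nitrogen. For the measured compounds named here, this replaces the whole aryl ring rather than one of its substituents, so no measured step covers it directly; the closest evidence is that methoxy, trifluoromethyl and dimethylamino on that ring all give numbers within the scatter of one another. No step beyond the scatter is therefore expected in this assay, and compound 4 is estimated at 800 nM, with a range of 400 nM to 1700 nM, meaning an expected step of a 1.1-fold lower number from compound 3 to compound 4 (0.04 log units; within the scatter).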

Compound 4, half-maximal inhibitory concentration: 980 nM
Compound 4: middle estimate off by 1.2-fold (0.09 log units), on the low side, within the range that was stated.
By their numbers in this assay, from the lowest: compounds 2, 1, 3 and 4 (each within the scatter of the next).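

In this assay pyridin-4-yl on the carbon with a double bond to nitrogen gives a 1.1-fold higher number from compound 3 to compound 4 (0.05 log units; within the scatter) and, against the other two aryl groups, a 1.5-fold higher number from compound 1 to compound 4 (0.17 log units; within the scatter) and a 1.6-fold higher number from compound 2 to compound 4 (0.19 log units; within the scatter) with all three steps within the scatter. Across these four compounds the number therefore stays within the scatter when the ring itself is exchanged for one with a hetero atom and fewer heavy atoms, whereas the earlier compounds covered only substituents on a carbon-only ring. Nothing available explains this flat read-out at the position.

Still open, on these data alone, is whether this position stays within the scatter with a carboxylic acid on the aryl ring or with a plain alkyl chain in place of the ring. Also open, as far as these compounds go, is whether pyridin-3-yl behaves like pyridin-4-yl here.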